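The source may report more compounds than this note shows. Statements on the series, on what has been measured and on what is new or still open speak of the compounds shown alone.

Compound 1 `CS/C(=N\C(=O)c1ccco1)NC(=O)c1ccco1` and compound 2 `O=C(/N=C(/NC(=O)c1ccco1)[Se]Cc1ccccc1)c1ccco1` share one core, and compound 3 `CS/C(=N\C(=O)c1cnc2ccccc2c1)NC(=O)c1cnc2ccccc2c1` and compound 4 `O=C(/N=C(/NC(=O)c1cnc2ccccc2c1)[Se]Cc1ccccc1)c1cnc2ccccc2c1` share another; the difference between the two cores is not broken down here. All four are considered in a functional assay on K562 cells (Homo sapiens) for cytotoxicity, read by MTT assay, with a stated time of 72 h; on this read-out lower numbers stand for stronger inhibition of growth and higher numbers for weaker inhibition of growth.

Compound 1 gives > 100000 nM, which is a limit of the assay and not a number. Compound 2 gives 44200 nM. The change between them is a group of 8 heavy atoms (7 carbon, 1 selenium; one six-membered aromatic ring of carbon only) in place of a group of 2 heavy atoms (1 carbon, 1 sulfur; no ring), on a carbon with a double bond to nitrogen, and it brought an at least 2.2-fold lower number from compound 1 to compound 2 (0.35 log units; beyond the scatter). How large that step really is cannot be said closely because of the limit of > 100000 nM in this assay, at which 2 of the 3 values shown sit.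

Compound 3 gives > 100000 nM, again a limit of the assay rather than a number.

Compound 4 carries the same change on its core, (a group of 8 heavy atoms (7 carbon, 1 selenium; one six-membered aromatic ring of carbon only) in place of a group of 2 heavy atoms (1 carbon, 1 sulfur; no ring), on a carbon with a double bond to nitrogen), at a place described in the same words as for compound 2. From compound 3 to compound 4 the step expected is an at least 2.2-fold lower number from compound 3 to compound 4 (0.34 log units; beyond the scatter), resting on the step of an at least 2.2-fold lower number from compound 1 to compound 2 (0.35 log units; beyond the scatter) seen on the other core. For compound 4 the expected value in this assay is therefore 45000 nM, within a range from 15000 nM to 150000 nM.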

Compound 4, concentration for total growth inhibition: 72600 nM
Compound 4: the middle estimate sits 1.6-fold (0.21 log units) below what was measured; measured number inside the range.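

In this assay, putting the selenium-bearing group with its six-membered aromatic ring in place of methylsulfanyl gives an at least 1.3-fold lower number from compound 3 to compound 4 (0.13 log units; that floor lies within the scatter) on the second core, so the lower number seen on the first core appears here too, although this floor alone does not clear the scatter. Set side by side, the two cores give this picture: the same change on two cores in this assay, an at least 2.2-fold lower number (0.35 log units; beyond the scatter) from compound 1 to compound 2 and an at least 1.3-fold lower number (0.13 log units; that floor lies within the scatter) from compound 3 to compound 4; the limit leaves it open whether they differ. On these data alone, the data therefore show that the change did not raise the number on either core, but they do not show that it carries over with the same size, and the true size of each step stays unknown because of the assay limit: the limit of > 100000 nM in this assay, at which 2 of the 4 values shown sit.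

The compounds shown leave open whether the selenium atom or the aromatic ring accounts for the step, which a sulfur atom carrying the same ring could help to separate. They also leave open how other groups at this carbon, such as an amine or a longer alkyl chain, would behave on either core.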